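The source may report more compounds than this note shows. Statements on the series, on what has been measured and on what is new or still open speak of the compounds shown alone.

Compound 1 `O=C(O)Cc1sc(C(c2ccc(F)cc2)c2ccc(F)cc2)nc1-c1ccco1` carries a furan-2-yl group on its core and, in an in vitro functional assay on HEK285-7 cells for antagonist activity at prostaglandin D2 receptor 2 (Homo sapiens), read by BRET and beta-arrestin recruitment (a lower number here means a stronger inhibitor, a higher number a weaker inhibitor), compound 1 gives 140 nM. Among the compounds with values here, the only other measured compound, compound 2 `O=C(O)Cc1sc(C(c2ccccc2)c2ccc(F)c(F)c2)nc1-c1ccc(F)cc1`, gives 64 nM in this assay, so compound 1 stands with the higher of the two numbers, and the gap to compound 2 lies beyond the usual scatter. Compound 2 differs from compound 1 in more than one place, so its number says nothing direct about any single change. Compound 3 `Cc1cc(-c2nc(C(c3ccc(F)cc3)c3ccc(F)cc3)sc2CC(=O)O)cnc1N` differs from compound 1 in one place: 6-amino-5-methylpyridin-3-yl in place of furan-2-yl on an aromatic carbon. Within the data shown here, no measured pair shows the effect of this exchange, so the expectation rests on compound 1 alone, and compound 3 is estimated at a number a little below that of compound 1, a step of a 1.4-fold lower number from compound 1 to compound 3 (0.15 log units; within the scatter) that may not leave the scatter. Compound 3 is therefore expected to give 100 nM, with a plausible range from 30 nM to 400 nM.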

Compound 3, half-maximal inhibitory concentration: > 100000 nM
Compound 3: only a limit was reported (the forecaster's own chance of this, stated with the estimate: 5%); middle value at least 1000-fold (3.00 log units) away from the limit.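

The aromatic carbon next to the ring nitrogen does not accept every aromatic group, which compound 1 and compound 2 could not show, as they differ in more than one place. Putting 6-amino-5-methylpyridin-3-yl in place of furan-2-yl here gives an at least 710-fold higher number from compound 1 to compound 3 (2.85 log units; beyond the scatter), so this single exchange on an otherwise unchanged molecule is enough to remove nearly all measurable inhibition in this assay. The number for compound 3 is a limit of the assay, so the true size of the step stays unknown: the limit of > 100000 nM in this assay, at which 1 of the 3 values shown sits.

The compounds shown do not separate the amine, the methyl and the six-membered ring as the source of this loss. A plain pyridin-3-yl group at this carbon, and versions carrying only the amine or only the methyl, would tell these parts apart.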